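Sulfonamide series on a shared core: methyl to chloro

This account rests on a few compounds, and the source may have more. Where it says the series, first, only, none or still open, it means among the compounds named here.

Measured so far in a functional assay on A549 cells (Homo sapiens) for antiproliferative activity, read by MTT assay, with a stated time of 72 h; a higher number here means a weaker inhibitor, a lower number a stronger inhibitor:
compound 1 `CN(C(=O)c1ccc(Br)cc1)c1ccc2[nH]c(-c3n[nH]c4ccccc34)cc2n1` gives 4250 nM
compound 2 `Cc1ccc(S(=O)(=O)N(C)c2ccc3[nH]c(-c4n[nH]c5ccccc45)cc3n2)cc1` gives 27100 nM

Among the measured compounds shown here, compound 2 has the highest number of the two, the weaker inhibitor, and its only neighbour is compound 1, with the step of a 6.4-fold higher number from compound 1 to compound 2 (0.80 log units; beyond the scatter). That step swaps both the linker and the para substituent, so it gives no clean read on either part alone.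

Compound 3 `CN(c1ccc2[nH]c(-c3n[nH]c4ccccc34)cc2n1)S(=O)(=O)c1ccc(Cl)cc1` keeps the sulfonyl linker of compound 2 and changes only the para position: chloro in place of methyl on an aromatic carbon. For the measured compounds named here, no measured step in this assay isolates that change; the one step that exists does not separate the para group from the linker. With nothing to lean on, the step of a 1.4-fold lower number from compound 2 to compound 3 (0.13 log units; within the scatter) is expected to fall within the scatter, leaning if anything to a slightly lower number.

Compound 3 is therefore estimated at 20000 nM in this assay, within 7000 nM to 60000 nM.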

Compound 3, half-maximal inhibitory concentration: 18200 nM
The estimate for compound 3 lay 1.1-fold (0.04 log units) above the measured number; the measured number falls inside the stated range.
By their numbers in this assay, from the lowest: compound 1; then compounds 3 and 2 (each within the scatter of the next).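

In this assay, chloro in place of methyl on the aromatic carbon of the sulfonyl-linked ring leaves the number within the scatter (a 1.5-fold lower number from compound 2 to compound 3 (0.17 log units; within the scatter)), so these two groups cannot be told apart at this place. With chloro in place of methyl, the gap to the carbonyl-linked compound remains beyond the scatter (a 4.3-fold higher number from compound 1 to compound 3 (0.63 log units; beyond the scatter)), so both sulfonyl compounds read as weaker than compound 1, although that step still changes the linker and the halogen together. No measurement on hand bears on the reason for either step.

Among the compounds shown here, no pair here holds the ring substituent constant while changing the linker. Going by these compounds, the size of a step in the linker alone stays open. Also open, on these data alone, is whether an amine or a carboxylic acid at this place would move the number beyond the scatter.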